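Ethyl in Place of Chloro: Expected Potency of Compound 3

The source may hold more compounds than are shown below. What is called first, only, known or untested is meant among the compounds shown, and "the series" means these compounds.

Of the compounds shown here, two have so far been measured in a functional assay on ileum (strain Hartley) for agonist activity at 5-hydroxytryptamine receptor 3A (Cavia porcellus); on this read-out higher numbers stand for higher potency (the scale is a negative logarithm) and lower numbers for lower potency. Compound 1 `Cc1cc(Cl)c2oc(N3CCN(C)CC3)nc2c1` gives 6.22 in this assay, and compound 2 `CN1CCN(c2nc3cccc(Cl)c3o2)CC1` gives 5.5 in this assay. For the measured compounds named here, the single step connecting them is a number 0.72 log units lower from compound 1 to compound 2 (beyond the scatter), which lies beyond the scatter of the measurement. Compound 2 therefore stands lowest of the two values, with compound 1 as its nearest and only neighbour.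

Compound 3 `CCc1cccc2nc(N3CCN(C)CC3)oc12` differs from compound 2 in one place: ethyl in place of chloro on an aromatic carbon. Going by the values given here, none of the measured steps bears on this exchange, since the only known step concerns the loss of a methyl group rather than the replacement of chloro by ethyl. Without any direct precedent, no step beyond the scatter is expected in this assay, and the estimate for compound 3 stays close to the value of compound 2, with a range wide enough to admit a modest shift in either direction. Compound 3 is estimated at 5.6, between 5 and 6.2, which means an expected step of a number 0.10 log units higher from compound 2 to compound 3 (within the scatter).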

Compound 3, negative logarithm of the half-maximal effective concentration: 5.48
Estimate against measurement, compound 3: 0.12 log units above; the measured number falls inside the stated range.
By their numbers in this assay, from the lowest: compounds 3 and 2 (each within the scatter of the next); then compound 1.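

In this assay, for the compounds shown here, ethyl in place of chloro gives a number 0.02 log units lower from compound 2 to compound 3 (within the scatter), the first reading at this position, an aromatic carbon ortho to a fused ring and meta to a fused ring. Here, the two carbon atoms of ethyl replace the single chlorine with no step beyond the scatter, whereas the one earlier step, at a different place on the core, was a number 0.72 log units lower from compound 1 to compound 2 (beyond the scatter). Nothing measured explains why this exchange leaves the number within the scatter.

The compounds shown leave open whether this holds only for the pair of chloro and ethyl or also for other groups at this position, such as a longer chain like propyl, an amine or a carboxylic acid. They also leave open whether the methyl group that separates compound 1 from compound 2 would bring a step of similar size if placed on compound 3, where ethyl stands instead of chloro.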